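Swapping pyridin-3-yl for 4-fluorophenyl on the alkyne

The compounds below may be only part of what the source reports. "The series", "measured", "known", "first", "only" and "open" are said of these compounds alone.

Compound 1 `COC(=O)c1sc2cc(C#Cc3cccnc3)cnc2c1N` is the starting point of this comparison. In a functional assay on MCF7 cells (Homo sapiens) for inhibition, read by sulforhodamine B assay, with a stated time of 48 h (on this read-out lower numbers stand for stronger inhibition of growth and higher numbers for weaker inhibition of growth), compound 1 gives > 150000 nM, which is a limit of the assay rather than a number. On the numbers shown, compound 1 therefore stands only at the limit of > 150000 nM in this assay, at which 1 of the 3 values shown sits, and its true value is not pinned down. Two compounds share its core and differ from it only in the group on the triple-bonded carbon. Compound 2 `COC(=O)c1sc2cc(C#Cc3ccsc3)cnc2c1N` gives 27700 nM in this assay. Compound 3 `COC(=O)c1sc2cc(C#Cc3cccc(OC)c3)cnc2c1N` gives 33400 nM in this assay. Against compound 1 there is an at least 5.4-fold lower number from compound 1 to compound 2 (0.73 log units; beyond the scatter) and an at least 4.4-fold lower number from compound 1 to compound 3 (0.65 log units; beyond the scatter), whereas between the two replacements there is only a 1.2-fold higher number from compound 2 to compound 3 (0.08 log units; within the scatter).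

Compound 4 `COC(=O)c1sc2cc(C#Cc3ccc(F)cc3)cnc2c1N` has not yet been measured. It differs from compound 1 by 4-fluorophenyl in place of pyridin-3-yl on a triple-bonded carbon. The two measured steps that exchange pyridin-3-yl for another ring at this position both gave at least modest lower numbers, and the two replacements landed close together, so the step to compound 4 is expected to go the same way. The expected step is an at least 5.0-fold lower number from compound 1 to compound 4 (0.69 log units; beyond the scatter), towards a lower number. Compound 4 is therefore estimated at 30000 nM, with a range from 10000 nM to 100000 nM.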

Compound 4, concentration for 50% growth inhibition: 29000 nM
Compound 4: middle estimate off by 1.0-fold (0.01 log units), on the high side; the measured number falls inside the stated range.
By their numbers in this assay, from the lowest: compounds 2, 4 and 3 (each within the scatter of the next). At a limit, above all of these: compound 1.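

In this assay, compound 4 adds a third replacement for pyridin-3-yl on a triple-bonded carbon, and it brings in a ring of carbon only that carries fluorine, with an at least 5.1-fold lower number from compound 1 to compound 4 (0.71 log units; beyond the scatter). It also stays level with the earlier replacements, with a 1.2-fold lower number from compound 3 to compound 4 (0.06 log units; within the scatter) and a 1.0-fold higher number from compound 2 to compound 4 (0.02 log units; within the scatter), so 4-fluorophenyl, 3-methoxyphenyl and thiophen-3-yl cannot be told apart on these numbers, and among the compounds shown only the pyridin-3-yl compound stands apart. From the compounds shown here alone, the true size of the step from compound 1 stays unknown, and it can be read only as a lower bound, because compound 1 stands at a limit: the limit of > 150000 nM in this assay, at which 1 of the 4 values shown sits.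

The compounds shown leave open whether any group at this place can bring the number well below the level shared by compounds 2, 3 and 4, since all three carry a single aromatic ring with at most one small substituent. They also leave open how an amine or a carboxylic acid on that ring, or a longer alkyl chain in place of the ring, would read in this assay.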